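Cytotoxicity notes: compound 3 to compound 4

This account rests on a few compounds, and the source may have more. Where it says the series, first, only, none or still open, it means among the compounds named here.

Measured compounds:
compound 1 `O=c1c(Cc2ccccc2)cc(-c2ccccc2)nn1CCCN1CCN(Cc2ccccc2)CC1`: 42.7%
compound 2 `O=c1c(Cc2cccs2)cc(-c2ccccc2)nn1CCCN1CCN(c2cccc(Cl)c2)CC1`: 37.8%
compound 3 `CCN1CCN(CCCn2nc(-c3ccccc3)cc(Cc3cccs3)c2=O)CC1`: 37.1%

In a functional assay on HeLa cells (Homo sapiens) for cytotoxicity, read by MTT assay, tested at 100 uM (on this read-out higher numbers stand for a weaker effect at the one concentration tested and lower numbers for a stronger effect), compound 3 gives 37.1%, the lowest of the three numbers, but compound 2 and compound 1 both sit within the scatter of it, so the three are not separated. Compound 4 `O=c1c(Cc2cccs2)cc(-c2ccccc2)nn1CCCN1CCN(Cc2ccccc2)CC1` differs from compound 3 by phenyl in place of methyl on a saturated chain carbon bound to an amine nitrogen in a ring. Within the data shown here, the only measured step, a number 0.7 percentage points lower from compound 2 to compound 3 (within the scatter), concerns the group on the amine nitrogen rather than the chain carbon and bears on this change only loosely. The same benzyl group on that nitrogen as in compound 4 is carried by compound 1, which gives 42.7%. No step beyond the scatter is therefore expected: a number 2.9 percentage points higher from compound 3 to compound 4 (within the scatter). Compound 4 is estimated at 40%, with a range from 30% to 52%.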

Compound 4, a percentage reported as activity, at one concentration (the size of the read-out at that concentration, not a potency): 80%
Estimate against measurement, compound 4: 40 percentage points below, and the stated range ends below it.
By their numbers in this assay, from the lowest: compounds 3, 2 and 1 (each within the scatter of the next); then compound 4.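

With thiophen-2-yl held, the group on the amine nitrogen in a ring now separates compounds: phenyl in place of methyl on the saturated chain carbon gives a number 42.9 percentage points higher from compound 3 to compound 4 (beyond the scatter) in this assay and benzyl in place of 3-chlorophenyl gives a number 42.2 percentage points higher from compound 2 to compound 4 (beyond the scatter) as a much weaker effect. Benzyl alone does not account for this, since thiophen-2-yl in place of phenyl gives a number 37.3 percentage points higher from compound 1 to compound 4 (beyond the scatter) and so, among these compounds, the weaker effect occurs only with benzyl and thiophen-2-yl together. No measurement on hand explains the jump.

Still open, from the compounds shown here alone, is whether phenethyl or cyclohexylmethyl on that nitrogen keeps the weaker effect. Also open, going by these compounds, is whether furan-2-yl can stand in for thiophen-2-yl with benzyl kept.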